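A few compounds are considered here, and "the series" means these few. Any claim that something is new, unique, unknown or untested is made for them only; others in the source may bear on it.

Measured in a functional assay on MCF7 cells (Homo sapiens) for antiproliferative activity, read by MTT assay, with a stated time of 48 h; a higher number here means a weaker inhibitor, a lower number a stronger inhibitor:
- compound 1 `COc1ccc(C(=O)/C=C/c2cccc(Br)c2Oc2c([N+](=O)[O-])cc(C(F)(F)F)cc2[N+](=O)[O-])cc1`: 2.32 ug/mL
- compound 2 `COc1ccc(C(=O)/C=C/c2cccc(Cl)c2Oc2c([N+](=O)[O-])cc(C(F)(F)F)cc2[N+](=O)[O-])cc1`: 1.83 ug/mL

Going by the values given here, compound 2, at 1.83 ug/mL, cannot be told apart from compound 1, the only other measured compound, since the two lie within the scatter. Compound 3 `O=C(/C=C/c1cccc(Cl)c1Oc1c([N+](=O)[O-])cc(C(F)(F)F)cc1[N+](=O)[O-])c1ccc(F)cc1` arises from compound 2 through fluoro in place of methoxy on an aromatic carbon, para to a large group. Among the compounds with values here, the single measured step, a 1.3-fold lower number from compound 1 to compound 2 (0.10 log units; within the scatter), is chloro in place of bromo on an aromatic carbon and lies within the scatter. Within the data shown here, no measured step replaces methoxy, so that step bears on this change only loosely. The data therefore give no reason to expect a shift beyond the scatter in this assay, in either direction, though the uncertainty is wide. The estimated step is a 1.1-fold higher number from compound 2 to compound 3 (0.04 log units; within the scatter). Compound 3 is expected at 2 ug/mL, with an estimated range of 0.7 ug/mL to 5.5 ug/mL.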

Compound 3, half-maximal inhibitory concentration: 5.17 ug/mL
Compound 3: middle estimate off by 2.6-fold (0.41 log units), on the low side; the range from low to high includes it.
By their numbers in this assay, from the lowest: compounds 2 and 1 (each within the scatter of the next); then compound 3.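

Going by these compounds alone, the change from 4-methoxyphenyl to 4-fluorophenyl is the first to move the number in this assay beyond the scatter, with a 2.8-fold higher number from compound 2 to compound 3 (0.45 log units; beyond the scatter), a modest step towards a weaker inhibitor. The earlier swap of chloro for bromo, a 1.3-fold lower number from compound 1 to compound 2 (0.10 log units; within the scatter), stayed within the scatter, so this aromatic carbon, para to a large group, is the first place shown where a single replacement separates two compounds, and methoxy carries the lower number of the pair. Nothing available accounts for this step.

On these data alone, whether an amine, a hydroxyl group or a longer alkoxy chain in place of the methoxy would match compound 2 or shift the number further remains open. So does whether the same replacement would give a similar step with bromo in place of chloro.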